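The source may report more compounds than this note shows. Statements on the series, on what has been measured and on what is new or still open speak of the compounds shown alone.

Measured compounds:
- compound 1, `CC(O)(C(=O)Nc1ccc(S(=O)(=O)c2cccc(O)c2)cc1)C(F)(F)F`: 18000 nM
- compound 2, `COc1ccccc1S(=O)(=O)c1ccc(NC(=O)C(C)(O)C(F)(F)F)cc1`: 1600 nM
- compound 3, `CC(O)(C(=O)Nc1ccc(S(=O)(=O)c2cccc(Cl)c2)cc1)C(F)(F)F`: 10000 nM

In a functional assay (Cavia porcellus) with sulfonylurea receptors; K-ATP channels (Homo sapiens) as the target (on this read-out lower numbers stand for stronger inhibition and higher numbers for weaker inhibition), compound 3 holds the second highest of the three numbers. Its nearest neighbour is compound 1, and that pair lies within the scatter, as the step of a 1.8-fold lower number from compound 1 to compound 3 (0.26 log units; within the scatter) shows; its furthest is compound 2, reached by a 6.3-fold higher number from compound 2 to compound 3 (0.80 log units; beyond the scatter). Compound 4, `CN(c1ccccc1)S(=O)(=O)c1ccc(NC(=O)C(C)(O)C(F)(F)F)cc1`, differs from compound 3 in one place: methyl(phenyl)amino in place of 3-chlorophenyl on a sulfonyl sulfur. Two of the measured steps bear on this change, as both also exchange the group on the sulfonyl sulfur: an 11-fold lower number from compound 1 to compound 2 (1.05 log units; beyond the scatter) and a 6.3-fold higher number from compound 2 to compound 3 (0.80 log units; beyond the scatter), each beyond the scatter. The third step, a 1.8-fold lower number from compound 1 to compound 3 (0.26 log units; within the scatter), exchanges only a ring substituent and stays within the scatter. Exchanges at the sulfonyl sulfur have therefore moved this read-out substantially, but in no consistent direction, and the group entering in compound 4 resembles none of those measured. A step beyond the scatter is expected for compound 4, its direction uncertain, with the estimated step of a 1.3-fold lower number from compound 3 to compound 4 (0.10 log units; within the scatter). Compound 4 is estimated at 8000 nM, between 1500 nM and 40000 nM.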

Compound 4, half-maximal inhibitory concentration: 2000 nM
Compound 4: the middle estimate sits 4.0-fold (0.60 log units) above what was measured; measured number inside the range.
By their numbers in this assay, from the lowest: compounds 2 and 4 (each within the scatter of the next); then compounds 3 and 1 (each within the scatter of the next).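

In this assay, methyl(phenyl)amino on the sulfonyl sulfur gives a lower number than either of the phenyl groups bearing a 3-substituent, with a 5.0-fold lower number from compound 3 to compound 4 (0.70 log units; beyond the scatter) and a 9.0-fold lower number from compound 1 to compound 4 (0.95 log units; beyond the scatter), both beyond the scatter. Against 2-methoxyphenyl, the same group gives a 1.3-fold higher number from compound 2 to compound 4 (0.10 log units; within the scatter), within the scatter, so among these four compounds this position accepts a nitrogen-linked group as well as a carbon-linked ring, and compound 2 and compound 4 read alike while compound 1 and compound 3 read alike. Nothing shown explains why these groups fall into two such sets.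

Going by these compounds, it remains open whether the methyl on that nitrogen matters, which a phenylamino group with a hydrogen there would test. Also open, on these data alone, is whether a piperidine on the sulfonyl sulfur, with no aromatic ring, would read like compound 4.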